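The compounds below may be only part of what the source reports. "The series", "measured", "known", "first", "only" and "open" are said of these compounds alone.

Working notes on the series. Compound 3 `COc1cc(C(=O)N2CCN(C(=O)c3cc(OC)c(OC)c(OC)c3)C(COC(=O)NCCC(C)C)C2)cc(OC)c1OC` carries an isopentylamino carbamate on the shared core; in a functional assay (Oryctolagus cuniculus) for inhibition of platelet-activating factor receptor (Cavia porcellus) (a higher number here means a weaker inhibitor, a lower number a stronger inhibitor), compound 3 gives 140 nM. Compound 1 `CCCCCCCC(=O)OCC1CN(C(=O)c2cc(OC)c(OC)c(OC)c2)CCN1C(=O)c1cc(OC)c(OC)c(OC)c1`, with heptyl on the carbonyl carbon in place of that group, gives 310 nM in this assay, and the step of a 2.2-fold lower number from compound 1 to compound 3 (0.35 log units; beyond the scatter) is modest though beyond the scatter. Compound 2 `CCC(CC)C(=O)OCC1CN(C(=O)c2cc(OC)c(OC)c(OC)c2)CCN1C(=O)c1cc(OC)c(OC)c(OC)c1`, the branched ester, gives 70 nM; 40 nM; 60 nM (3 entries) in this assay; the spread of its repeats the several entries of compound 2 in this assay, 70 nM; 40 nM; 60 nM (3 entries) shows the ordinary scatter of the method. Compound 3 therefore stands lowest of the two single numbers in this assay, with compound 1 nearest.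

Compound 4 `CCCCCCCCNC(=O)OCC1CN(C(=O)c2cc(OC)c(OC)c(OC)c2)CCN1C(=O)c1cc(OC)c(OC)c(OC)c1` is not yet measured. It differs from compound 3 by hexyl in place of isopropyl on a saturated chain carbon, two bonds along the chain from an amide-type nitrogen. Among the compounds with values here, no measured step matches this change directly. Within the data shown here, what the esters show is that compound 1, with the long straight chain, gives the higher number and compound 2, with the shorter branched chain, the lower one; the one measured step, from the straight-chain ester to the branched carbamate, is modest. Since the change to compound 4 lengthens the chain and removes the branch, a modest rise is expected, a 1.8-fold higher number from compound 3 to compound 4 (0.25 log units; within the scatter). Compound 4 is thus expected to give 250 nM in this assay, estimated between 100 nM and 600 nM.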

Compound 4, half-maximal inhibitory concentration: 370 nM
The estimate for compound 4 lay 1.5-fold (0.17 log units) below the measured number, and the stated range covers the measured number.
By their numbers in this assay, from the lowest: compound 3; then compounds 1 and 4 (each within the scatter of the next).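

In this assay, the carbamate chain now has a measured change at this position: hexyl in place of isopropyl on a saturated chain carbon, two bonds along the chain from an amide-type nitrogen, gives a 2.6-fold higher number from compound 3 to compound 4 (0.42 log units; beyond the scatter), so the isopentylamino result does not carry over to the octylamino chain. Set against the heptyl ester, the octylamino carbamate gives a 1.2-fold higher number from compound 1 to compound 4 (0.08 log units; within the scatter), so these two long straight chains cannot be told apart in this assay, and the earlier step, a 2.2-fold lower number from compound 1 to compound 3 (0.35 log units; beyond the scatter), holds only for the isopentylamino chain among the carbamates shown. The step to the octylamino chain is modest but beyond the scatter, and the repeats of the branched ester show the size of that scatter: the several entries of compound 2 in this assay, 70 nM; 40 nM; 60 nM (3 entries)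

Chain length and branching change together in the step to the octylamino chain, so the two effects cannot be separated here; a straight pentylamino chain or a branched chain of octylamino length would bear on that. Also open, going by these compounds, is how an amine or a carboxylic acid at the end of the chain would read in this assay.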